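Ring substituent variation across compounds 1 to 4

The source may report more compounds than this note shows. Statements on the series, on what has been measured and on what is new or still open speak of the compounds shown alone.

Measured so far in an assay on CHO cells for antagonist activity at transient receptor potential cation channel subfamily V member 1 (Homo sapiens), read by FLIPR and calcium flux; on this read-out lower numbers stand for stronger inhibition and higher numbers for weaker inhibition:
- compound 1, `CC(C(=O)NCc1ccc(C(F)(F)F)nc1CCC(C)(C)C)c1ccc(NS(C)(=O)=O)c(F)c1`: compound 1 gives 0.6 nM
- compound 2, `CC1C=C(c2nc(C(F)(F)F)ccc2CNC(=O)C(C)c2ccc(NS(C)(=O)=O)c(F)c2)CCC1`: compound 2 gives 0.2 nM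
- compound 3, `CC(C(=O)NCc1ccc(C(F)(F)F)nc1C1=CCC(C(C)(C)C)CC1)c1ccc(NS(C)(=O)=O)c(F)c1`: compound 3 gives 0.2 nM

Compound 3 stands level with compound 2 at the digits printed, the two together giving the lowest numbers of the three, with compound 1 the furthest away. The ring-bearing compounds separate from the open-chain compound 1: a 3.0-fold lower number from compound 1 to compound 2 (0.48 log units; beyond the scatter) and a 3.0-fold lower number from compound 1 to compound 3 (0.48 log units; beyond the scatter), both beyond the scatter. Between the two ring variants the alkyl pattern on the ring made no difference: no change at the digits printed from compound 2 to compound 3 (within the scatter).

Compound 4, `CC(C(=O)NCc1ccc(C(F)(F)F)nc1C1=CCC(C)(C)CC1)c1ccc(NS(C)(=O)=O)c(F)c1`, keeps the ring and changes only its alkyl groups: 4,4-dimethylcyclohex-1-en-1-yl in place of 4-(tert-butyl)cyclohex-1-en-1-yl on an aromatic carbon. The step that bears on it most directly is the exchange of ring alkyl groups from compound 2 to compound 3, which stayed within the scatter, while both steps from compound 1 show that the ring itself, not the alkyl pattern, carries the gain. In this assay compound 4 is therefore expected to sit close to compound 3, with a step of about a 1.3-fold higher number from compound 3 to compound 4 (0.10 log units; within the scatter), that is none beyond the scatter. Compound 4 is estimated at 0.25 nM, with a range from 0.1 nM to 0.7 nM.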

Compound 4, inhibition constant: 0.2 nM
Estimate against measurement, compound 4: 1.3-fold (0.10 log units) above; the measured number falls inside the stated range.
By their numbers in this assay, from the lowest: compounds 2, 3 and 4 (each within the scatter of the next); then compound 1.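

In this assay, going from 4-(tert-butyl)cyclohex-1-en-1-yl, with 10 heavy atoms, to 4,4-dimethylcyclohex-1-en-1-yl, with 8 heavy atoms, leaves the number in place (no change at the digits printed from compound 3 to compound 4 (within the scatter)), and the exchange from 3-methylcyclohex-1-en-1-yl reads the same (no change at the digits printed from compound 2 to compound 4 (within the scatter)). On the aromatic carbon next to the ring nitrogen, three different alkyl patterns on the six-membered carbon ring now cannot be told apart, and the separation from the open-chain 3,3-dimethylbutyl group holds for a third ring-bearing compound (a 3.0-fold lower number from compound 1 to compound 4 (0.48 log units; beyond the scatter)). No measurement at hand accounts for this tolerance of the ring alkyl pattern.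

The compounds shown leave open whether the ring double bond is needed, which a saturated cyclohexyl group would test, and whether a morpholine or a piperidine could stand at this position in place of the carbon ring. With compounds 2, 3 and 4 together at the same printed digits, they also leave open how far the alkyl groups matter at all, a question that a plain cyclohex-1-en-1-yl group without alkyl groups would address.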